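A few compounds are considered here, and "the series" means these few. Any claim that something is new, unique, unknown or untested is made for them only; others in the source may bear on it.

Compound 1 `Cn1c(/C=C/C(=O)c2ccccc2)cc(Br)c1Br`: in a functional assay on KB403 cells (Homo sapiens) for cytotoxicity, read by MTT assay, with stated times of 6 h and 48 h (on this read-out higher numbers stand for weaker inhibition and lower numbers for stronger inhibition), compound 1 gives only a limit of the assay, >= 100000 nM.
Compound 2 `Cn1c(/C=C/C(=O)c2ccc(O)cc2O)cc(Br)c1Br`: in this assay compound 2 gives 12000 nM.

Going by the values given here, compound 2 thus holds the only measured number in this assay; the one other value shown is a limit, (the limit of >= 100000 nM in this assay, at which 1 of the 2 values shown sits), and no step between measured compounds is given, so the two values simply stand side by side. The compound still to be measured is compound 3 `Cn1c(/C=C/C(=O)c2ccc(O)cc2)cc(Br)c1Br`. It differs from compound 2 by hydrogen in place of hydroxy on an aromatic carbon. Compound 2 carries two hydroxy groups and compound 1 none; compound 3 keeps one of them. The change from compound 2 to compound 3 in this assay is expected to run toward weaker inhibition and to exceed the scatter, with a real chance that only a limit is returned. Compound 3 is estimated at 40000 nM, within 12000 nM to 150000 nM, an expected step of a 3.3-fold higher number from compound 2 to compound 3 (0.52 log units; beyond the scatter).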

Compound 3, half-maximal inhibitory concentration: >= 100000 nM
Compound 3: only a limit was reported; the forecaster's own chance of this, stated with the estimate: 30%; middle value at least 2.5-fold (0.39 log units) from the limit.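

In this assay hydrogen in place of hydroxy on the aromatic carbon ortho to a large group and meta to a hydroxy group gives an at least 8.3-fold higher number from compound 2 to compound 3 (0.92 log units; beyond the scatter) and ties the drop to this single position, which the two earlier compounds could not do, as they differ by both hydroxy groups at once. Going by these compounds alone, compound 3 gives >= 100000 nM as a limit of the assay, so the one hydroxy group it keeps does not by itself bring a measured number. The step from compound 1 to compound 3 cannot be read, and the values shown now gather at the limit: the limit of >= 100000 nM in this assay, at which 2 of the 3 values shown sit.

From the compounds shown here alone, whether the hydroxy group ortho to a large group would suffice without the other one stays open. So does whether a methoxy group or an amine at that position could stand in for the hydroxy group.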